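From 4-hydroxyphenyl to 4-methoxyphenyl on a shared core

This account rests on a few compounds, and the source may have more. Where it says the series, first, only, none or still open, it means among the compounds named here.

In a functional assay on PC-3 cells (Homo sapiens) for antiproliferative activity, read by MTT assay, with a stated time of 72 h (on this read-out lower numbers stand for stronger inhibition and higher numbers for weaker inhibition), compound 1 (`O=C(N/N=C/c1cccc(Cl)c1Cl)Nc1ccc(Oc2ccnc3[nH]ccc23)cc1`) gives "not active" (no number reported) and no number at all. Among the compounds with values here, compound 2 (`O=C(N/N=C/c1ccc(O)cc1)Nc1ccc(Oc2ccnc3[nH]ccc23)cc1`) gives 4920 nM and so holds the only number so far, with one further entry lacking a number to set it against. Compound 3 (`COc1ccc(/C=N/NC(=O)Nc2ccc(Oc3ccnc4[nH]ccc34)cc2)cc1`) is still to be measured in this assay and departs from compound 2 in a single place (methyl in place of hydrogen on an oxygen on an aromatic ring): methyl in place of hydrogen on an oxygen on an aromatic ring, turning 4-hydroxyphenyl into 4-methoxyphenyl. Within the data shown here, no step between measured compounds is available as a guide, and the data offer no direction for this change. The expected change, a 1.1-fold higher number from compound 2 to compound 3 (0.05 log units; within the scatter), is not estimated to go beyond the usual scatter. In this assay compound 3 is expected to read 5500 nM within an estimated range of 1800 nM to 17000 nM.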

Compound 3, half-maximal inhibitory concentration: "not active" (no number reported)
No number was reported for compound 3; there is nothing to compare the estimate with.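

In this assay compound 3 gives "not active" (no number reported) and compound 2 gives 4920 nM, so no step can be read between them. The compounds shown leave open how large the difference between hydroxy and methoxy is on this shared core. No further data bear on this result.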